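The source may hold more compounds than are shown below. What is called first, only, known or untested is meant among the compounds shown, and "the series" means these compounds.

The measured compounds:
Compound 1, `O=C(CCCCCCc1ccccc1)c1ncc(-c2ccc([N+](=O)[O-])cc2)o1`, in an assay (Rattus norvegicus) for inhibition of Fatty-acid amide hydrolase 1 (Homo sapiens); on this read-out higher numbers stand for weaker inhibition and lower numbers for stronger inhibition: 50 nM
Compound 2, `O=C(CCCCCCc1ccccc1)c1ncc(-c2ncccc2C(=O)O)o1`, in this assay: only a limit, > 50 nM
Compound 3, `O=C(CCCCCCc1ccccc1)c1ncc(-c2ccncn2)o1`, in this assay: 2.3 nM

Among the two numbers shown, compound 3 stands lowest; its nearest neighbour is compound 1, and the step runs a 22-fold lower number from compound 1 to compound 3 (1.34 log units; beyond the scatter). Compound 2 sits at the limit of > 50 nM in this assay, at which 1 of the 3 values shown sits, so the step from compound 2 to compound 3 can only be given as an at least 21-fold lower number from compound 2 to compound 3 (1.33 log units; beyond the scatter). From the compounds shown here alone, the step from compound 1 to compound 2 is likewise open in size, a number no lower from compound 1 to compound 2 (the limit leaves the size open).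

Compound 4, `O=C(CCCCCCc1ccccc1)c1ncc(I)o1`, differs from compound 3 by iodo in place of pyrimidin-4-yl on an aromatic carbon.

Every measured step exchanges one six-membered aromatic group for another on the same carbon of the shared core; none removes that ring altogether, so the measured steps bear on the present change only loosely. They do show that what sits on this carbon moves the number in this assay by large amounts, and a single halogen in place of pyrimidin-4-yl is expected to give a higher number than compound 3, well beyond the scatter, though its size is uncertain.

The step from compound 3 to compound 4 is therefore estimated as a 13-fold higher number from compound 3 to compound 4 (1.12 log units; beyond the scatter). Compound 4 is expected to give 30 nM in this assay, within a range from 6 nM to 200 nM.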

Compound 4, inhibition constant: 3 nM
Compound 4: the middle estimate sits 10-fold (1.00 log units) above what was measured, outside the stated range (below it).
By their numbers in this assay, from the lowest: compounds 3 and 4 (each within the scatter of the next); then compound 1.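

Iodo in place of pyrimidin-4-yl takes the six-membered aromatic ring off this carbon next to the ring oxygen, and in this assay the step reads a 1.3-fold higher number from compound 3 to compound 4 (0.12 log units; within the scatter), so compound 3 and compound 4 cannot be told apart. The earlier steps shown here only exchanged one six-membered aromatic group for another, whereas this one shows that such a ring is not required on this carbon for a number at this level, and that a single iodine atom can stand in its place. Against the 4-nitrophenyl group, iodo gives a 17-fold lower number from compound 1 to compound 4 (1.22 log units; beyond the scatter), and against the 3-carboxypyridin-2-yl group the reading is an at least 16-fold lower number from compound 2 to compound 4 (1.22 log units; beyond the scatter), which rests on a limit rather than a number: the limit of > 50 nM in this assay, at which 1 of the 4 values shown sits.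

The compounds shown leave open whether it is iodo in particular that holds the number at this level, or whether chloro, a methyl or an amine on the same carbon would do the same. They also leave open how far these numbers depend on the chain on the carbonyl, which is the same throughout, so a shorter chain remains an open case.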